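Allyloxy to methyl on the amine nitrogen: metabolic stability

This account rests on a few compounds, and the source may have more. Where it says the series, first, only, none or still open, it means among the compounds named here.

The series shares one core: compound 1 is `CON/C(=N\C1=NC(=O)C(=O)N1C(C)C)Nc1ccc(Cl)c(Cl)c1`, compound 2 is `CCON/C(=N\C1=NC(=O)C(=O)N1C(C)C)Nc1ccc(Cl)c(Cl)c1`, compound 3 is `C=CCON/C(=N\C1=NC(=O)C(=O)N1C(C)C)Nc1ccc(Cl)c(Cl)c1`. In an in vitro ADME assay on microsomes from liver (Homo sapiens) for metabolic stability, read by LC-MS (on this read-out lower numbers stand for a shorter-lived compound and higher numbers for a longer-lived compound), compound 1 gives > 1 h, a limit of the assay. Compound 2 gives > 1 h, likewise a limit. Compound 3 gives > 1 h, also a limit. Compound 3 thus sits at the limit of > 1 h in this assay, at which 3 of the 3 values shown sit. The steps a step that the two limits leave unreadable from compound 1 to compound 2, a step that the two limits leave unreadable from compound 1 to compound 3 and a step that the two limits leave unreadable from compound 2 to compound 3 carry no readable size. Compound 4 is `CN/C(=N\C1=NC(=O)C(=O)N1C(C)C)Nc1ccc(Cl)c(Cl)c1`; the change is methyl in place of allyloxy on an amine nitrogen. For the measured compounds named here, no measured step touches this position, so no size can be carried over. Compound 4 is expected near the same limit, with wide uncertainty: the estimate is 1.2 h, from 0.4 h to 3.5 h. The expected step is a step that the limit leaves unreadable from compound 3 to compound 4.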

Compound 4, half-life: > 1 h
Compound 4 was reported as a limit; the forecaster's own chance of this, stated with the estimate: 55%; the middle value does not contradict the limit.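

In this assay no step among compound 1, compound 2, compound 3 and compound 4 can be read: the limit of > 1 h in this assay, at which 4 of the 4 values shown sit.

Going by these compounds, whether methyl, methoxy, ethoxy and allyloxy on the amine nitrogen differ in half-life at all stays open.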